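The compounds below may be only part of what the source reports. "The series", "measured", "known", "first", "only" and "open" are said of these compounds alone.

Measured so far, in a functional assay on HepG2 cells (Homo sapiens) for antiproliferative activity, read by CCK-8 assay, with a stated time of 72 h, tested at 2 uM; on this read-out higher numbers stand for a stronger effect at the one concentration tested and lower numbers for a weaker effect:
compound 1 `Nc1ccccc1NC(=O)/C=C/c1ccc(Cn2cnc3c(Nc4ccccc4)nc(Cl)nc32)cc1` gives 16.4%
compound 2 `Nc1ccccc1NC(=O)c1ccc(Cn2cnc3c(Nc4ccccc4)nc(Cl)nc32)cc1` gives 49.6%
compound 3 `Nc1ccccc1NC(=O)c1ccc(COCNc2nc(Nc3ccccc3)c3ncn(C4CCCC4)c3n2)cc1` gives 37.5%

Compound 2 stands highest of the three numbers in this assay; compound 3 is nearest, compound 1 furthest, both beyond the scatter. Among the compounds with values here, the one measured step, a number 33.2 percentage points higher from compound 1 to compound 2 (beyond the scatter), concerns the link between the benzylic ring and the carbamoyl group, with (2-aminophenyl)carbamoyl in place of 2-((2-aminophenyl)carbamoyl)ethenyl.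

Compound 4 `Nc1ccccc1NC(=O)c1ccc(Cn2cnc3c(Nc4cccc(Cl)c4)nc(Cl)nc32)cc1` differs from compound 2 by chloro in place of hydrogen on an aromatic carbon. Within the data shown here, no measured step touches the anilino ring, so the step from compound 1 to compound 2 gives no guide here and no pattern can be claimed. The expected step is a number 0.4 percentage points higher from compound 2 to compound 4 (within the scatter), not beyond the scatter. For compound 4 the estimate in this assay is 50%, expected to lie between 30% and 70%.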

Compound 4, a percentage reported as inhibition, at one concentration (the size of the read-out at that concentration, not a potency): 29.9%
For compound 4 the middle estimate is 20.1 percentage points above the measured one; the whole stated range lies above it.
By their numbers in this assay, from the lowest: compound 1; then compounds 4 and 3 (each within the scatter of the next); then compound 2.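

In this assay, within the data shown here, the anilino ring turns out not to be neutral: the change from anilino to (3-chlorophenyl)amino gives a number 19.7 percentage points lower from compound 2 to compound 4 (beyond the scatter) and this is the first measured change on that ring. A single chloro on an aromatic carbon, meta to a large group, is thus enough to move the read-out beyond the scatter, and downward. Nothing at hand explains this drop.

As far as these compounds go, whether the drop is particular to chloro stays open, as a fluoro, methoxy or amino group on the same aromatic carbon would show. From the compounds shown here alone, whether it carries over to the core of compound 3 also stays open.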